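Methyl in Place of Hydrogen on a Weakly Active Thioether

The compounds below may be only part of what the source reports. "The series", "measured", "known", "first", "only" and "open" are said of these compounds alone.

Among the compounds with values here, compound 1 `Cc1cc(=O)oc2cc(SCc3cccc(OC(F)(F)F)c3)ccc12` is the only compound with a number: in a functional assay on KB cells (Homo sapiens) for antiproliferative activity, read by sulforhodamine B assay, with a stated time of 72 h (on this read-out lower numbers stand for stronger inhibition of growth and higher numbers for weaker inhibition of growth), compound 1 gives 14800 nM. Compound 2 `CCc1cc(=O)c2ccc(Sc3cccc(Cl)n3)cc2o1` stands differently. In this assay compound 2 is reported only as a limit, > 31400 nM. Compound 2 therefore sits at the limit of > 31400 nM in this assay, at which 1 of the 2 values shown sits, and nothing more than that is known of it. Compound 3 `CCc1cc(=O)c2ccc(Sc3cccc(Cl)n3)c(C)c2o1` differs from compound 2 by methyl in place of hydrogen on an aromatic carbon. Within the data shown here, no step between two measured compounds exists here, so the size of this change has no precedent in the data. With compound 2 already at a limit, the step that the limit leaves unreadable from compound 2 to compound 3 is expected to be none beyond the scatter, in no clear direction. Compound 3 is accordingly estimated at 40000 nM, with a range from 15000 nM to 100000 nM, and a fair chance that this assay again reports only a limit.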

Compound 3, concentration for 50% growth inhibition: > 30100 nM
Compound 3: a limit, no number; the forecaster's own chance of this, stated with the estimate: 65%; the middle value does not contradict the limit.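

In this assay compound 3 gives > 30100 nM as a limit, not a number. Compound 2 likewise gives > 31400 nM as a limit, so no step can be read between compound 2 and compound 3. As far as these compounds go, whether methyl in place of hydrogen on an aromatic carbon changes growth inhibition at all remains open.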